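The source may report more compounds than this note shows. Statements on the series, on what has been measured and on what is new or still open speak of the compounds shown alone.

Measured so far in an ADME assay on HepG2 cells (Homo sapiens) for cytotoxicity, with a stated time of 72 h; on this read-out higher numbers stand for an effect only at larger amounts of compound and lower numbers for an effect already at smaller amounts (both entries are limits, not numbers):
Compound 1 `O=C(Nc1ccc(-c2ccccc2)cc1)c1cc([N+](=O)[O-])ccc1Cl` gives > 27000 nM
Compound 2 `COC(=O)C1CCN(c2cc(Cl)c(C(=O)Nc3cc(-c4nc5ccccc5s4)ccc3OC)cc2[N+](=O)[O-])CC1` gives > 25000 nM

Compound 1 stands at > 27000 nM as a limit of this assay and not as a number. Within the data shown here, the only other entry, for compound 2, is also a limit, so the series offers no numerical value and no measured step to scale from.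

Compound 3 `O=C(Nc1ccc(Cl)cc1)c1cc([N+](=O)[O-])ccc1Cl` differs from compound 1 by chloro in place of phenyl on an aromatic carbon in a single place: chloro in place of phenyl on an aromatic carbon, para to a large group. Among the measured compounds shown here, with no measured step to go by, no shift beyond the usual scatter is expected in this assay and no direction can be assigned. This expectation rests on compound 1 with its limit > 27000 nM and on nothing firmer. The expected change, a step that the limit leaves unreadable from compound 1 to compound 3 as estimated here, should be read with that caution. For compound 3 the estimated value is 28000 nM with an expected range from 12000 nM to 60000 nM and a result in the form of a limit is also expected to be likely.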

Compound 3, half-maximal effective concentration: > 27000 nM
Compound 3 ended at the assay's limit; the forecaster's own chance of this, stated with the estimate: 65%; the middle value is on the limit's open side.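

In this assay compound 3 gives > 27000 nM, which is a limit and not a number. No step between compound 1 and compound 3 can be read, since both entries are limits: the limit of > 27000 nM in this assay, at which 2 of the 3 values shown sit.

The compounds shown leave open whether chloro in place of phenyl shifts this read-out at all, and at what concentration any of them would reach a half-maximal effect.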